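Removing tert-butoxycarbonyl from compound 3

A few compounds are considered here, and "the series" means these few. Any claim that something is new, unique, unknown or untested is made for them only; others in the source may bear on it.

compound 1 `CC(C)[C@H](NC(=O)c1cc(Cl)ccc1OCCN)C(=O)Nc1ccc([N+](=O)[O-])cc1Cl` gives > 10000 nM as a limit
compound 2 `CC(C)C[C@H](NC(=O)c1cc(Cl)ccc1OCCN)C(=O)Nc1ccc([N+](=O)[O-])cc1Cl` gives > 10000 nM as a limit
compound 3 `CC[C@@H](C)[C@H](NC(=O)c1cc(Cl)ccc1OCCNC(=O)OC(C)(C)C)C(=O)Nc1ccc([N+](=O)[O-])cc1Cl` gives 10500 nM as a number

In a functional assay on MCF7 cells (Homo sapiens) for inhibition, read by MTT assay, with a stated time of 72 h (on this read-out higher numbers stand for weaker inhibition and lower numbers for stronger inhibition), compound 1 stands at > 10000 nM and this is a limit of the assay, not a number. Compound 2 stands at > 10000 nM and this too is only a limit. Within the data shown here, compound 3 gives 10500 nM in this assay and holds the only true number in the set.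

Compound 4 `CC[C@@H](C)[C@H](NC(=O)c1cc(Cl)ccc1OCCN)C(=O)Nc1ccc([N+](=O)[O-])cc1Cl` differs from compound 3 by hydrogen in place of tert-butoxycarbonyl on an amine nitrogen and so has hydrogen in place of tert-butoxycarbonyl on an amine nitrogen. Among the measured compounds shown here, no measured step covers this change. For the measured compounds named here, the one measured step is a step that the two limits leave unreadable from compound 1 to compound 2 and it gives no size to carry over. The nearest guide is compound 1 and compound 2, which share the 2-aminoethyl end of compound 4 and sit at the limit of > 10000 nM in this assay, at which 2 of the 3 values shown sit, in the series.

In this assay the expected result is a 1.3-fold higher number from compound 3 to compound 4 (0.12 log units; within the scatter) and any drift is expected toward weaker inhibition, with no step beyond the scatter. Compound 4 is estimated at 14000 nM with an expected range from 6000 nM to 40000 nM and a report of only a limit is expected to be more likely than a number.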

Compound 4, half-maximal inhibitory concentration: > 10000 nM
Compound 4: only a limit was reported; the forecaster's own chance of this, stated with the estimate: 65%; the middle value is on the limit's open side.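

In this assay no new step can be read: compound 4 is reported only as a limit, so its steps from compound 1, compound 2 and compound 3 have no readable size. The compounds shown leave open whether hydrogen in place of tert-butoxycarbonyl on an amine nitrogen shifts the read-out at all.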